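The source may hold more compounds than are shown below. What is called first, only, known or untested is meant among the compounds shown, and "the series" means these compounds.

Compound 2 has the structure `O=[N+]([O-])c1ccc2c(c1)c([N+](=O)[O-])cc[n+]2[O-]`, and in a physicochemical assay for lipophilicity (on this read-out lower numbers stand for lower lipophilicity and higher numbers for higher lipophilicity), compound 2 gives 0.9. Compound 1, with the structure `CCCCc1ccc2c(c1)c([N+](=O)[O-])cc[n+]2[O-]`, differs from compound 2 by butyl in place of nitro on an aromatic carbon, and in this assay compound 1 gives 3.11. That single change brought a number 2.21 log units higher from compound 2 to compound 1 (beyond the scatter). Compound 3 carries the structure `O=[N+]([O-])c1ccc2c(c1)c(NO)cc[n+]2[O-]`; it differs from compound 2 by hydroxyamino in place of nitro on an aromatic carbon, and in this assay compound 3 gives -0.28, the lowest of the three numbers, so that a number 1.18 log units lower from compound 2 to compound 3 (beyond the scatter). Compound 4, not yet measured in this assay, has the structure `CCCCc1ccc2c(c1)c(NO)cc[n+]2[O-]`. Going by the values given here, it differs from compound 3 by butyl in place of nitro on an aromatic carbon, the same change as the one made from compound 2 to compound 1, at a place described in the same words; the two cores differ only by the change already told for compound 3 against compound 2. Because the earlier change gave a number 2.21 log units higher from compound 2 to compound 1 (beyond the scatter), a step of similar size is expected here, namely a number 2.18 log units higher from compound 3 to compound 4 (beyond the scatter). Compound 4 is therefore estimated at 1.9, with a likely range from 1.3 to 2.5.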

Compound 4, partition coefficient: 2.1
Beside the measured number, compound 4's estimate is 0.20 log units below it; measured number inside the range.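

In this assay the swap of nitro for butyl on an aromatic carbon gave a number 2.38 log units higher from compound 3 to compound 4 (beyond the scatter) on the core of compound 3 and a number 2.21 log units higher from compound 2 to compound 1 (beyond the scatter) on the core of compound 2, so it carried over between these two cores in the same direction and with a large step on each. The other change in this set of four, hydroxyamino in place of nitro on an aromatic carbon, likewise gave a number 1.01 log units lower from compound 1 to compound 4 (beyond the scatter) and a number 1.18 log units lower from compound 2 to compound 3 (beyond the scatter) on the two cores, but this single pair of cores does not show that the butyl change would carry over to any further core in the series. No measurement here explains why the steps run as they do.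

The compounds shown leave open what a longer chain, such as hexyl, or a shorter one, such as methyl, would give at that same place. They also leave open how an amine or a carboxylic acid would behave there in place of nitro, on either core.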